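Triazole-linked tricyclic ketones: cytotoxicity on A549 cells

A few compounds are considered here, and "the series" means these few. Any claim that something is new, unique, unknown or untested is made for them only; others in the source may bear on it.

Measured compounds:
- compound 1 `COc1ccc(-c2cn(C[C@H]3c4c(ccc(OS(=O)(=O)c5ccc(C)cc5)c4C)[C@@H]4CC[C@@]5(C)C[C@]43CC5=O)nn2)cc1`: > 20000 nM
- compound 2 `Cc1c(O)ccc2c1[C@H](Cn1cc(-c3ccc(C(F)(F)F)cc3)nn1)[C@@]13CC(=O)[C@@](C)(CC[C@@H]21)C3`: > 20000 nM

Both measured compounds were run in a functional assay on A549 cells (Homo sapiens) for cytotoxicity, read by MTT assay, with a stated time of 4 days; on this read-out lower numbers stand for stronger inhibition and higher numbers for weaker inhibition. Compound 1 reaches only a limit of this assay, > 20000 nM, not a number. Compound 2 likewise reaches only a limit of this assay, > 20000 nM. Where compound 2 stands is therefore known only as a bound, and the one further value shown is also a bound: the limit of > 20000 nM in this assay, at which 2 of the 2 values shown sit. For the measured compounds named here, no step between the two measured compounds is given, and nothing beyond the two limits is known about how the series behaves.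

Compound 3 `COc1ccc(-c2cn(C[C@H]3c4c(ccc(O)c4C)[C@@H]4CC[C@@]5(C)C[C@]43CC5=O)nn2)cc1` has not been measured. It differs from compound 2 by methoxy in place of trifluoromethyl on an aromatic carbon, in words: methoxy in place of trifluoromethyl on an aromatic carbon. Going by the values given here, with both neighbours sitting at the limit, no direction for the step is supported by the numbers; the expected step from compound 2 to compound 3 is a number no higher from compound 2 to compound 3 (the limit leaves the size open), that is, none beyond the scatter. Compound 3 is expected to give about 20000 nM in this assay, with a range from 8000 nM to 40000 nM, and most likely to be reported only as a limit.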

Compound 3, half-maximal inhibitory concentration: > 20000 nM
Compound 3 was reported as a limit (the forecaster's own chance of this, stated with the estimate: 75%); the middle value sits exactly at the limit.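

Compound 3 sits at the limit of this assay, as do compound 1 and compound 2, so neither the step from compound 2 to compound 3 nor the step from compound 1 to compound 3 can be read: the limit of > 20000 nM in this assay, at which 3 of the 3 values shown sit.

The compounds shown leave open whether any change on the shared core gives a number inside the range of this read-out.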